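The compounds below may be only part of what the source reports. "The series", "measured", "known", "first", "only" and "open" are said of these compounds alone.

Working notes on the series.

Two compounds are measured. Compound 1 `CS(=O)(=O)c1ccc(-c2cnc3[nH]cc(-c4nnc(-c5ccncc5)o4)c(=O)c3c2)cc1` gives 2.35% in a functional assay on MCF7 cells (Homo sapiens) for inhibition, read by MTT assay, with a stated time of 24 h, tested at 5 uM; a higher number here means more inhibition of growth at the concentration tested, a lower number less inhibition of growth. Compound 2 `Cc1ccc(-c2nnc(-c3c[nH]c4ncc(-c5ccc(S(C)(=O)=O)cc5)cc4c3=O)o2)cc1` gives 6.26% in the same assay. Among the compounds with values here, the step of a number 3.9 percentage points higher from compound 1 to compound 2 (within the scatter) is the only measured step, and it lies within the scatter. Compound 2 holds the higher of the two numbers, but with the step to compound 1 within the scatter, no order between the two can be read from the data.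

Compound 3 `Cc1cccc(-c2nnc(-c3c[nH]c4ncc(-c5ccc(S(C)(=O)=O)cc5)cc4c3=O)o2)c1` is not yet measured. It differs from compound 2 in one place: 3-methylphenyl in place of 4-methylphenyl on an aromatic carbon. Within the data shown here, no measured step bears directly on this change; the one step available, from compound 1 to compound 2, exchanges a different group at the same aromatic carbon and stays within the scatter. With both measured numbers low and close together, compound 3 is expected to fall near compound 2, with the step of a number 0.3 percentage points lower from compound 2 to compound 3 (within the scatter) expected to stay within the scatter. The estimate for compound 3 in this assay is 6%, with a range from -4% to 16%.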

Compound 3, percent growth inhibition at one concentration: 1.86%
Compound 3: the middle estimate sits 4.1 percentage points above what was measured; low and high end bracket the measured number.
By their numbers in this assay, from the lowest: compounds 3, 1 and 2 (each within the scatter of the next).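

Exchanging 4-methylphenyl for 3-methylphenyl on the aromatic carbon of the five-membered ring gives, in this assay, a number 4.4 percentage points lower from compound 2 to compound 3 (within the scatter), so this first test of where the methyl group sits on the phenyl ring separates nothing in this assay. Exchanging pyridin-4-yl for 3-methylphenyl at the same carbon gives a number 0.5 percentage points lower from compound 1 to compound 3 (within the scatter), so neither a second carbon-only ring nor the ring with its nitrogen can be set apart from the others, and the three groups tried at this position cannot be put in any order. Nothing at hand bears on why these readings stay so close together.

All three groups on this carbon are six-membered aromatic rings, so the compounds shown say nothing about whether an amine, a carboxylic acid or a longer alkyl chain at this position would give a reading clear of the scatter. Also open is whether changes elsewhere on the shared core would separate compounds in this assay, as every change shown here sits at this one carbon.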